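The source may hold more compounds than are shown below. What is called first, only, known or untested is meant among the compounds shown, and "the series" means these compounds.

In an assay on cells for inhibition of HSP60/HSP10 (Homo sapiens), with a stated time of 60 min (on this read-out higher numbers stand for weaker inhibition and lower numbers for stronger inhibition), compound 1 `COc1ccc(Cl)cc1S(=O)(=O)Nc1ccc(-c2nc3ccccc3o2)cc1` gives only a limit of the assay, > 100000 nM. Compound 1 therefore stands at the limit of > 100000 nM in this assay, at which 1 of the 2 values shown sits, with no number of its own. Compound 2 `O=S(=O)(Nc1ccc2oc(-c3ccccc3)nc2c1)c1cccc(O)c1` gives 76000 nM in this assay. Compound 3 `O=S(=O)(Nc1ccc(-c2nc3ccccc3o2)cc1)c1ccc(Cl)cc1` differs from compound 1 by 4-chlorophenyl in place of 5-chloro-2-methoxyphenyl on a sulfonyl sulfur. Among the measured compounds shown here, no measured pair shows this change, so the size of the step is open; a step within the scatter, in either direction, is the most that can be expected. Compound 3 is expected to give 100000 nM in this assay, between 40000 nM and 250000 nM. The estimated step is a number no higher from compound 1 to compound 3 (the limit leaves the size open).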

Compound 3, half-maximal inhibitory concentration: 61000 nM
The estimate for compound 3 lay 1.6-fold (0.21 log units) above the measured number; low and high end bracket the measured number.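

In this assay, the change to 4-chlorophenyl on a sulfonyl sulfur gives an at least 1.6-fold lower number from compound 1 to compound 3 (0.21 log units; that floor lies within the scatter). With this group the series gives a number of its own at this position, where 5-chloro-2-methoxyphenyl gave only a limit. The true size of the step stays open because compound 1 carries no number: the limit of > 100000 nM in this assay, at which 1 of the 3 values shown sits.

The compounds shown leave open how the number would respond to an amine or a carboxylic acid on the ring at this position, or to a longer chain on the sulfonyl sulfur.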